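Swapping One Aromatic Ring in a Receptor Antagonist Series

The source may report more compounds than this note shows. Statements on the series, on what has been measured and on what is new or still open speak of the compounds shown alone.

Measured compounds:
Compound 1 `O=C(O)Cc1sc(C(c2ccc(F)cc2)c2ccc(F)cc2)nc1-c1ccnc(N2CCCC2)c1` gives 80% in an in vitro functional assay on HEK285-7 cells for antagonist activity at prostaglandin D2 receptor 2 (Homo sapiens), read by BRET and beta-arrestin recruitment; on this read-out lower numbers stand for smaller maximal responses and higher numbers for larger maximal responses.
Compound 2 `NS(=O)(=O)c1ccc(-c2nc(C(c3ccc(F)cc3)c3ccc(F)cc3)sc2CC(=O)O)cc1` gives 80% in this assay.
Compound 3 `O=C(O)Cc1sc(C(c2ccc(F)cc2)c2ccc(F)cc2)nc1-c1ccnc(F)c1` gives 80% in this assay.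

Compound 3 stands level with the other two: its maximal response matches compound 1 and compound 2 at the digits shown, and no step among the three reaches beyond the usual scatter. Compound 4 `O=C(O)Cc1sc(C(c2ccc(F)cc2)c2ccc(F)cc2)nc1-c1ccco1` has not yet been tested. It differs from compound 3 in one place: furan-2-yl in place of 2-fluoropyridin-4-yl on an aromatic carbon.

Among the compounds with values here, two measured steps touch the same position. From compound 1 to compound 3 the maximal response moved no change at the digits printed from compound 1 to compound 3 (within the scatter), and from compound 2 to compound 3 it moved no change at the digits printed from compound 2 to compound 3 (within the scatter). Across these three quite different groups the maximal response stayed put, so this position has so far tolerated replacement without a visible shift in this assay. On that basis the expected step from compound 3 to compound 4 is no change at the digits printed from compound 3 to compound 4 (within the scatter), that is none beyond the scatter. Compound 4 is therefore estimated at 80% in this assay, with a likely range from 66% to 92%.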

Compound 4, largest response reached (reported as efficacy), in percent of the reference or control that the assay uses: 80%
The estimate for compound 4 equals the measured number at the digits printed; measured number inside the range.
By their numbers in this assay, from the lowest: compounds 1, 2, 3 and 4 (each within the scatter of the next).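

With furan-2-yl, the only five-membered aromatic ring among the four compounds, the result in this assay is no change at the digits printed from compound 3 to compound 4 (within the scatter) at the position next to the ring nitrogen. Set against the other two groups, the picture is the same: no change at the digits printed from compound 2 to compound 4 (within the scatter) for 4-sulfamoylphenyl and no change at the digits printed from compound 1 to compound 4 (within the scatter) for 2-(pyrrolidin-1-yl)pyridin-4-yl, so among these compounds, going from a six-membered to a five-membered aromatic ring leaves no visible mark on the maximal response. No measurement is available that accounts for this flat result.

Every group shown here is aromatic, so it remains open whether a saturated ring such as cyclohexyl or a plain methyl group would give the same response. The maximal response also leaves open how much of each compound is needed to reach it.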